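This account rests on a few compounds, and the source may have more. Where it says the series, first, only, none or still open, it means among the compounds named here.

Values in an ADME assay on liver for metabolic stability, with Liver microsome (Homo sapiens) as the target, read by LC-MS, using microsomes; on this read-out higher numbers stand for fast clearance and lower numbers for slow clearance:
- compound 1 `O=C(NCc1cc(Cl)ccc1-n1cnnn1)[C@@H]1C[C@@H]2C[C@@H]2N1C(=O)[C@H](O)CC1CC1`: < 12 mL.min-1.g-1 (a limit)
- compound 2 `O=C(NCc1cc(Cl)ccc1-n1cnnn1)[C@@H]1CC=NN1C(=O)[C@H](O)c1ccccc1F`: 16 mL.min-1.g-1
- compound 3 `O=C(NCc1cc(Cl)ccc1-n1cnnn1)[C@@H]1C[C@H]2C[C@H]2N1C(=O)[C@H](O)CC1CC1`: 25 mL.min-1.g-1

Compound 3 gives 25 mL.min-1.g-1, and compound 2 gives 16 mL.min-1.g-1; these two values lie within the usual scatter of each other. Compound 1 reports only a limit, < 12 mL.min-1.g-1. Within the data shown here, the only measured step is an at least 2.0-fold higher number from compound 1 to compound 3 (0.31 log units; beyond the scatter), and it rests on the limit of < 12 mL.min-1.g-1 in this assay, at which 1 of the 3 values shown sits, and on (the fact that compounds 1 and 3 differ only in the configuration as drawn).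

Compound 4 `O=C(NCc1cc(Cl)ccc1-n1cnnn1)[C@@H]1C[C@H]2C[C@H]2N1C(=O)[C@H](O)c1cccc(F)c1` keeps the drawn ring configuration of compound 3 and has 3-fluorophenyl in place of cyclopropylmethyl on a saturated chain carbon bound to a carbonyl carbon and an oxygen on a saturated carbon. Among the measured compounds shown here, no measured step covers this exchange, and the configurational step gives no direct size for it. Compound 2 also has a fluorophenyl group on that kind of carbon and gives 16 mL.min-1.g-1, but its core differs as well, so it offers only a rough guide to the level in this assay. For the measured compounds named here, with that value and compound 3 at 25 mL.min-1.g-1 as the only guides, no change beyond the scatter is expected. The expected step is a 1.1-fold higher number from compound 3 to compound 4 (0.05 log units; within the scatter). For compound 4 the estimated value is 28 mL.min-1.g-1, with an expected range of 13 mL.min-1.g-1 to 60 mL.min-1.g-1.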

Compound 4, intrinsic clearance in microsomes: 32 mL.min-1.g-1
Compound 4: the middle estimate sits 1.1-fold (0.06 log units) below what was measured; low and high end bracket the measured number.
By their numbers in this assay, from the lowest: compounds 2, 3 and 4 (each within the scatter of the next). At a limit, below all of these: compound 1.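

In this assay, 3-fluorophenyl in place of cyclopropylmethyl on a saturated chain carbon bound to a carbonyl carbon and an oxygen on a saturated carbon gives a 1.3-fold higher number from compound 3 to compound 4 (0.11 log units; within the scatter), with the drawn ring configuration held constant. Among these compounds, this is the first measured exchange at this position on one shared core, and it shows that an aromatic ring carrying fluorine can replace the small saturated group here with no shift beyond the scatter in this read-out, a statement that holds for this single pair only. Nothing in hand accounts for this step or gives a cause for it.

Open, on these data alone, is how a phenyl without fluorine, a longer chain, an amine or a carboxylic acid on this same carbon would read in this assay, since one exchange cannot show how far this flat response extends. Also open, as far as these compounds go, is whether the ring configuration of compound 1, whose result is only a limit, would give a step of similar size when 3-fluorophenyl occupies this position.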